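The compounds below may be only part of what the source reports. "The series", "measured", "known", "first", "only" and "open" are said of these compounds alone.

In a functional assay on B16 cells (Mus musculus) for antiproliferative activity, read by MTT assay, with a stated time of 24 h (a lower number here means a stronger inhibitor, a higher number a weaker inhibitor), compound 1 `C=CCOc1ccc2c(=O)c(-c3cc(OC)c(OC)cc3OC)coc2c1` gives 5100 nM, compound 2 `C#CCOc1ccc2c(=O)c(-c3cc(OC)c(OC)cc3OC)coc2c1` gives 4500 nM, and compound 3 `COc1cc(OC)c(-c2coc3cc(OCc4ccc(Br)cc4)ccc3c2=O)cc1OC` gives 1180 nM, the lowest number of the three. Compound 4 `COc1cc(OC)c(-c2coc3cc(OCc4ccccc4C(F)(F)F)ccc3c2=O)cc1OC` places 2-(trifluoromethyl)phenyl in the position of the 4-bromophenyl of compound 3, on a saturated chain carbon bound to an oxygen on an aromatic ring: 2-(trifluoromethyl)phenyl in place of 4-bromophenyl on a saturated chain carbon bound to an oxygen on an aromatic ring. Two measured steps introduce the 4-bromophenyl: a 4.3-fold lower number from compound 1 to compound 3 (0.64 log units; beyond the scatter) and a 3.8-fold lower number from compound 2 to compound 3 (0.58 log units; beyond the scatter), both modest. The third, a 1.1-fold lower number from compound 1 to compound 2 (0.05 log units; within the scatter), does not involve a phenyl group. Among the compounds with values here, no measured step exchanges one substituted phenyl for another, so the guidance is loose, and no step beyond the scatter is expected in this assay. The estimated step is a 1.3-fold higher number from compound 3 to compound 4 (0.10 log units; within the scatter). For compound 4 the expected value is 1500 nM, with an estimated range of 600 nM to 3800 nM.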

Compound 4, half-maximal inhibitory concentration: 8550 nM
For compound 4 the middle estimate is 5.7-fold (0.76 log units) below the measured one; the whole stated range lies below it.
By their numbers in this assay, from the lowest: compound 3; then compounds 2, 1 and 4 (each within the scatter of the next).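

In this assay, 2-(trifluoromethyl)phenyl in place of 4-bromophenyl gives a 7.2-fold higher number from compound 3 to compound 4 (0.86 log units; beyond the scatter), so a phenyl ring on this chain carbon does not by itself bring the lower number. Compound 4 also stands level with the smaller groups, with a 1.9-fold higher number from compound 2 to compound 4 (0.28 log units; within the scatter) and a 1.7-fold higher number from compound 1 to compound 4 (0.22 log units; within the scatter), both within the scatter.

From the compounds shown here alone, whether the change comes from losing bromine or from adding trifluoromethyl stays open, as does how an unsubstituted phenyl, a longer chain or an amine would read here. No measurement shown explains the difference between these two phenyl groups.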